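This account rests on a few compounds, and the source may have more. Where it says the series, first, only, none or still open, it means among the compounds named here.

Compound 1 `COc1ccc(Nc2nc3ccccc3nc2S(=O)(=O)c2ccc(C)cc2)cc1`: in a functional assay on PC-3 cells (Homo sapiens) for cytotoxicity, read by MTT assay, with a stated time of 72 h (on this read-out lower numbers stand for stronger inhibition and higher numbers for weaker inhibition), compound 1 gives only a limit, > 50000 nM.
Compound 2 `COc1cc(Nc2nc3ccccc3nc2S(=O)(=O)c2ccc(C)cc2)cc(OC)c1`: in this assay compound 2 gives 2940 nM.
Compound 3 `Cc1ccc(S(=O)(=O)c2nc3ccccc3nc2Nc2ccc(N)cc2)cc1`: in this assay compound 3 gives 5000 nM.

For the measured compounds named here, compound 2 is one of only two compounds that give a number rather than a limit in this assay, and the two numbers lie close together: a 1.7-fold higher number from compound 2 to compound 3 (0.23 log units; within the scatter). Compound 1 sits at the limit of > 50000 nM in this assay, at which 1 of the 3 values shown sits, so the steps from it, an at least 17-fold lower number from compound 1 to compound 2 (1.23 log units; beyond the scatter) and an at least 10-fold lower number from compound 1 to compound 3 (1.00 log units; beyond the scatter), are both large and both concern the aryl group on the nitrogen of the shared core.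

Compound 4 `COc1ccc(S(=O)(=O)c2nc3ccccc3nc2Nc2cc(OC)cc(OC)c2)cc1` differs from compound 2 elsewhere: methoxy in place of methyl on an aromatic carbon. Going by the values given here, none of the measured steps touches this part of the molecule; all three change the aryl amine, and the 4-methylphenyl is kept in compound 1, compound 2 and compound 3 alike. Among the compounds with values here, there is therefore no measured step that bears on the change from compound 2 to compound 4, and no step beyond the scatter is expected in this assay in either direction.

Compound 4 is accordingly estimated at 3000 nM in this assay, within a range from 1000 nM to 9000 nM, which means an expected step of a 1.0-fold higher number from compound 2 to compound 4 (0.01 log units; within the scatter).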

Compound 4, half-maximal inhibitory concentration: 6220 nM
For compound 4 the middle estimate is 2.1-fold (0.32 log units) below the measured one, within the range that was stated.
By their numbers in this assay, from the lowest: compounds 2, 3 and 4 (each within the scatter of the next, the first and the last beyond it). At a limit, above all of these: compound 1.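

For the compounds shown here, this is the first change in the piece at the 4-methylphenyl rather than at the aryl group on the nitrogen, and in this assay the move to 4-methoxyphenyl gives a 2.1-fold higher number from compound 2 to compound 4 (0.33 log units; beyond the scatter). With the 3,5-dimethoxyphenyl held in place, the position para to a large group is therefore not silent, although this modest step is smaller than the large step on the nitrogen side, an at least 17-fold lower number from compound 1 to compound 2 (1.23 log units; beyond the scatter). Nothing measured here bears on why the number moves with methoxy in place of methyl.

With only methyl and methoxy shown at this position, it remains open whether an amine, a hydroxyl or a longer chain such as ethoxy would give a number close to that of compound 2 or compound 4, or one further away in either direction. From the compounds shown here alone, it also remains open whether methoxy in place of methyl would give a step of similar size and the same direction on another aryl group on the nitrogen, such as the 4-aminophenyl of compound 3, so this single pair cannot yet be read as a general trend for the position.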